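From nitro to methyl in compound 4

A few compounds are considered here, and "the series" means these few. Any claim that something is new, unique, unknown or untested is made for them only; others in the source may bear on it.

- compound 1 `Nc1ccccc1NC(=O)CCCNCC(=O)Nc1cccc(Cl)c1`: 11600 nM
- compound 2 `Nc1ccccc1NC(=O)c1ccc(NCC(=O)Nc2ccc([N+](=O)[O-])cc2)cc1`: 600 nM
- compound 3 `Nc1ccccc1NC(=O)CCCNCC(=O)Nc1ccccc1Cl`: 21800 nM

In a functional assay on HCT-116 cells (Homo sapiens) for inhibition, read by MTT assay, with a stated time of 2 days (on this read-out lower numbers stand for stronger inhibition of growth and higher numbers for weaker inhibition of growth), compound 2 gives the lowest number of the three, and its gaps to compound 1 and compound 3 lie beyond the scatter. Compound 4 `Cc1ccc(NC(=O)CNc2ccc(C(=O)Nc3ccccc3N)cc2)cc1` differs from compound 2 by methyl in place of nitro on an aromatic carbon. For the measured compounds named here, the only measured step, a 1.9-fold higher number from compound 1 to compound 3 (0.27 log units; within the scatter), belongs to the core of compound 1 and moves a chlorine rather than exchanging nitro for methyl. It therefore offers little guidance, and no step beyond the scatter is expected. The expected step is a 1.3-fold higher number from compound 2 to compound 4 (0.12 log units; within the scatter). The estimated value for compound 4 is 800 nM, with an expected range of 270 nM to 2400 nM.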

Compound 4, concentration for 50% growth inhibition: 12600 nM
Estimate against measurement, compound 4: 16-fold (1.20 log units) below, and the stated range ends below it.
By their numbers in this assay, from the lowest: compound 2; then compounds 1, 4 and 3 (each within the scatter of the next).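

In this assay, methyl in place of nitro on an aromatic carbon para to a large group gives a 21-fold higher number from compound 2 to compound 4 (1.32 log units; beyond the scatter) and so shows that, on the core of compound 2, the number depends strongly on what this one place carries. The earlier compounds shown here showed only a chlorine moved on another core, with no change beyond the scatter. Nothing at hand gives a reason for the size of this step. As far as these compounds go, whether a nitrile, a trifluoromethyl or an amine here would stay close to compound 2 or to compound 4 remains open. So does whether nitro would matter as much on the core of compound 1.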